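Amine substituent: benzyl replaced by methylsulfonyl

The compounds below may be only part of what the source reports. "The series", "measured", "known", "first", "only" and "open" are said of these compounds alone.

Compound 2 `CC(C)CC[C@@]1(NCc2ccccc2)C(=O)C(C2=NS(=O)(=O)c3cc(NS(C)(=O)=O)ccc3N2)=C(O)c2ccccc21` stands lowest of the three measured numbers: in an in vivo ADME assay on the whole organism (strain Sprague-Dawley) for pharmacokinetics, with Rattus norvegicus as the target, at a dose of 5 mg/kg by the oral route (a lower number here means that a smaller share of the oral dose reaches the circulation, a higher number that a larger share of the oral dose reaches the circulation), compound 2 gives 13.3%, whereas compound 1 `CON[C@]1(CCC(C)C)C(=O)C(C2=NS(=O)(=O)c3cc(NS(C)(=O)=O)ccc3N2)=C(O)c2ccccc21` gives 34.1% and compound 3 `CC(C)(C)CCC1(NCc2ccc3ccccc3c2)C(=O)C(C2=NS(=O)(=O)c3cc(NS(C)(=O)=O)ccc3N2)=C(O)c2ccccc21` gives 28.1%. Within the data shown here, the only measured step at the amine nitrogen is a number 20.8 percentage points lower from compound 1 to compound 2 (beyond the scatter), and it bears directly on the change considered here, since it removed a small group from that nitrogen and installed benzyl. Compound 4 `CC(C)CC[C@@]1(NS(C)(=O)=O)C(=O)C(C2=NS(=O)(=O)c3cc(NS(C)(=O)=O)ccc3N2)=C(O)c2ccccc21` differs from compound 2 in that (methylsulfonyl in place of benzyl on an amine nitrogen). Among the measured compounds shown here, no measured pair covers methylsulfonyl at this position, so the reversal of the benzyl step is a guide only in direction. Compound 4 is therefore expected to come out higher, an expected step of a number 11.7 percentage points higher from compound 2 to compound 4 (beyond the scatter). For compound 4 the estimate is 25%, with a range from 8% to 45%.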

Compound 4, oral bioavailability: 0%
For compound 4 the middle estimate is 25 percentage points above the measured one, and the stated range ends above it.
By their numbers in this assay, from the lowest: compound 4; then compound 2; then compounds 3 and 1 (each within the scatter of the next).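

At the amine nitrogen, methylsulfonyl lowers the number in this assay further than benzyl does (a number 13.3 percentage points lower from compound 2 to compound 4 (beyond the scatter)) and well beyond the level of methoxy (a number 34.1 percentage points lower from compound 1 to compound 4 (beyond the scatter)). The smaller group therefore does not restore the number toward compound 1, and heavy-atom count alone does not order methoxy, benzyl and methylsulfonyl on this nitrogen. No measurement at hand accounts for the drop.

As far as these compounds go, whether an acetyl group or a plain methyl on this nitrogen would sit nearer compound 1 or compound 4 remains open. Also open, from the compounds shown here alone, is whether other sulfonyl groups, such as phenylsulfonyl, follow methylsulfonyl here.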